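The source may report more compounds than this note shows. Statements on the series, on what has been measured and on what is new or still open speak of the compounds shown alone.

Among the compounds with values here, compound 1 `C=CCn1/c(=N\C#N)n([C@H]2OC(CO)[C@@H](O)[C@H]2O)c2cc(N)nc(O)c21` and compound 2 `CC1OC(n2c(=O)n(C)c3c(O)nc(N)nc32)[C@H](O)[C@@H]1O` are the two measured members of this small set. In a functional assay on the whole organism (B cells) with Mus musculus as the target (a higher number here means a larger maximal response, a lower number a smaller maximal response), compound 1 gives 85%. In this assay compound 2 gives 0%, the lower of the two numbers, and the gap to compound 1 lies beyond the usual scatter. Compound 3 `Cn1c(=O)n(C2OC(CO)[C@@H](O)[C@H]2O)c2nc(N)nc(O)c21` differs from compound 2 in one place: hydroxy in place of hydrogen on a saturated chain carbon bound to a saturated ring carbon. Within the data shown here, no measured pair shows this change, so its size in this assay cannot be read from the numbers at hand. A small upward step is expected for compound 3, a number 10 percentage points higher from compound 2 to compound 3 (within the scatter), not clearly beyond the scatter. Compound 3 is thus estimated at 10%, within a range from 0% to 35%.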

Compound 3, largest response reached (reported as maximal response), in percent of the reference or control that the assay uses: 99%
Beside the measured number, compound 3's estimate is 89 percentage points below it; the measured number lies above the stated range.
By their numbers in this assay, from the lowest: compound 2; then compound 1; then compound 3.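

In this assay the change from methyl to hydroxymethyl, hydroxy in place of hydrogen on a saturated chain carbon bound to a saturated ring carbon, gives the first step read in this series (a number 99 percentage points higher from compound 2 to compound 3 (beyond the scatter)). This position is therefore not a minor one for the maximal response: a single change here moves the read-out far beyond the scatter. Nothing at hand accounts for the size of this step. The compounds shown leave open whether hydroxy is specifically required here. An aminomethyl, a methoxymethyl or a longer chain such as hydroxyethyl at this place would test that.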